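The compounds below may be only part of what the source reports. "The series", "measured", "known", "first", "only" and "open" are said of these compounds alone.

The study turns on a shared core carrying a nitrile, an amino group and a triazole whose aromatic nitrogen bears a substituted phenyl ring. Of the compounds shown here, three have been measured in an ADME assay on HUVEC cells (Homo sapiens) for antiproliferative activity, read by MTT assay, with a stated time of 48 h; on this read-out higher numbers stand for weaker inhibition and lower numbers for stronger inhibition. Compound 1 `N#CC1=C(N)Oc2c(c3nc4ccccc4nc3c3ccccc23)C12C(=O)N(Cc1cnnn1-c1ccc(F)cc1)c1ccccc12` reaches only the limit of the assay, giving > 50000 nM. Compound 2 `Cc1ccc(Cl)cc1-n1nncc1CN1C(=O)C2(C(C#N)=C(N)Oc3c2c2nc4ccccc4nc2c2ccccc32)c2ccccc21` likewise stops at a limit, giving > 50000 nM. Because (the limit of > 50000 nM in this assay, at which 2 of the 3 values shown sit), the step that the two limits leave unreadable from compound 1 to compound 2 cannot be read. For the measured compounds named here, compound 3 `N#CC1=C(N)Oc2c(N)cc3nc4ccccc4nc3c2C12C(=O)N(Cc1cnnn1-c1ccccc1Br)c1ccccc12` is the only one with a number, giving 34200 nM in this assay, so it stands alone among the values shown rather than above or below the others.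

Compound 4 `Cc1ccc(Cl)cc1-n1nncc1CN1C(=O)C2(C(C#N)=C(N)Oc3c(N)cc4nc5ccccc5nc4c32)c2ccccc21` has not yet been measured. It differs from compound 3 in one place: 5-chloro-2-methylphenyl in place of 2-bromophenyl on an aromatic nitrogen. Going by the values given here, the only measured step that touches the same kind of change, from compound 1 to compound 2, was left unreadable by the two limits, so no readable step bears on this change and its size is unknown. The author therefore expects no step beyond the usual scatter, with the estimated step of a 1.1-fold higher number from compound 3 to compound 4 (0.05 log units; within the scatter) for compound 4 in this assay. The estimated value for compound 4 is 38000 nM, in the range from 14000 nM to 100000 nM, with a fair chance that only a limit is reported.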

Compound 4, half-maximal inhibitory concentration: > 50000 nM
Compound 4 ended at the assay's limit; the forecaster's own chance of this, stated with the estimate: 45%; middle value at least 1.3-fold (0.11 log units) from the limit.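

For the compounds shown here, changing 2-bromophenyl to 5-chloro-2-methylphenyl on the aromatic nitrogen gives the first step at this position that can be read in this assay, and it is only a floor: an at least 1.4-fold higher number from compound 3 to compound 4 (0.16 log units; that floor lies within the scatter) is all that the two values allow. That floor does not separate the two aryl groups beyond the usual scatter, so the change is not shown to weaken the inhibition, although the true step may be larger. On these data alone, the earlier step between two limits still cannot be read, and the size of this new step stays open at its upper end: (the limit of > 50000 nM in this assay, at which 3 of the 4 values shown sit).

The compounds shown leave open how an unsubstituted phenyl ring, or a phenyl ring carrying a methoxy group, an amine or a carboxylic acid, would read on the core of compound 3, and whether any of these would give a number well clear of the limit. They also leave open whether 2-bromophenyl would give a number rather than a limit on the core of compound 1.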